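This account rests on a few compounds, and the source may have more. Where it says the series, first, only, none or still open, it means among the compounds named here.

Two cores carry the same substituent question. Compound 3 `COc1ccc2c(c1)CCC/C2=N\NCc1nc2cc([N+](=O)[O-])ccc2[nH]1` and compound 2 `COc1ccc2c(c1)CCC/C2=N\NCc1nc2ccccc2[nH]1` share one core; compound 1 `NS(=O)(=O)c1nnc(NCc2nc3cc([N+](=O)[O-])ccc3[nH]2)s1` and compound 4 `NS(=O)(=O)c1nnc(NCc2nc3ccccc3[nH]2)s1` share another; how the two cores differ is not broken down here.

In a functional assay on MCF7 cells (Homo sapiens) for cytotoxicity, read by MTT assay (a lower number here means a stronger inhibitor, a higher number a weaker inhibitor), compound 3 gives 78000 nM and compound 2 gives 63000 nM. The change hydrogen in place of nitro on an aromatic carbon produced a 1.2-fold lower number from compound 3 to compound 2 (0.09 log units; within the scatter).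

In this assay compound 1 gives 230000 nM, the highest of the three measured numbers. The change to compound 4, (hydrogen in place of nitro on an aromatic carbon), is the same change as that from compound 3 to compound 2.

Because the measured step of a 1.2-fold lower number from compound 3 to compound 2 (0.09 log units; within the scatter) lies within the scatter, a step of about the same size, a 1.2-fold lower number from compound 1 to compound 4 (0.06 log units; within the scatter), is expected for compound 4. Compound 4 is therefore estimated at 200000 nM in this assay, with a likely range from 100000 nM to 400000 nM.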

Compound 4, half-maximal inhibitory concentration: 228000 nM
Beside the measured number, compound 4's estimate is 1.1-fold (0.06 log units) below it; the range from low to high includes it.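

On the core of compound 1, hydrogen in place of nitro on an aromatic carbon gives a 1.0-fold lower number from compound 1 to compound 4 (0.00 log units; within the scatter) in this assay, and the two cores agree on this change: the same change on two cores in this assay, a 1.2-fold lower number (0.09 log units; within the scatter) from compound 3 to compound 2 and a 1.0-fold lower number (0.00 log units; within the scatter) from compound 1 to compound 4, 1.2-fold (0.09 log units) apart, within the scatter of two such steps. Within these two pairs, the change therefore carries from one core to the other as a step within the scatter. This does not show that the step would stay as small on a further core or among compounds with much lower numbers, and two pairs set no general rule.

The compounds shown leave open what another group on that aromatic carbon, such as an amine or a carboxylic acid, would give. The difference between the two cores themselves also remains unresolved into single changes.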